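Aryl ketone variation in a triazolothiadiazine series

The source may report more compounds than this note shows. Statements on the series, on what has been measured and on what is new or still open speak of the compounds shown alone.

Measured so far in a functional assay on PC-3 cells (Homo sapiens) for cytotoxicity, read by MTT assay, with a stated time of 48 h; on this read-out lower numbers stand for stronger inhibition and higher numbers for weaker inhibition:
- compound 1, `COc1cc(-c2nnc3n2NC(c2ccco2)C(C(=O)c2ccccc2F)S3)cc(OC)c1OC`: > 100000 nM, a limit of the assay rather than a number
- compound 2, `COc1cc(-c2nnc3n2NC(c2ccco2)C(C(=O)c2ccc(Br)cc2)S3)cc(OC)c1OC`: 36400 nM
- compound 3, `COc1cc(-c2nnc3n2NC(c2cccs2)C(C(=O)c2ccc(C)cc2)S3)cc(OC)c1OC`: 5090 nM

Within the data shown here, compound 2 stands at the highest of the two numbers; compound 3 sits lower, beyond the scatter, but differs from compound 2 in two places, so no single step is read there. Compound 4, `COc1cc(-c2nnc3n2NC(c2ccco2)C(C(=O)c2ccccc2)S3)cc(OC)c1OC`, differs from compound 2 by hydrogen in place of bromo on an aromatic carbon. Among the measured compounds shown here, the only measured step on the carbonyl aryl group, an at least 2.7-fold lower number from compound 1 to compound 2 (0.43 log units; beyond the scatter), exchanges one halophenyl for another and shows this position matters, though it does not cover removal of a substituent. For the measured compounds named here, no measured pair tests loss of the para group. Compound 4 is therefore expected to show a modest rise, a 1.4-fold higher number from compound 2 to compound 4 (0.14 log units; within the scatter), giving an estimate of 50000 nM with a range of 15000 nM to 150000 nM.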

Compound 4, half-maximal inhibitory concentration: 64300 nM
Beside the measured number, compound 4's estimate is 1.3-fold (0.11 log units) below it, and the stated range covers the measured number.
By their numbers in this assay, from the lowest: compound 3; then compounds 2 and 4 (each within the scatter of the next). At a limit, above all of these: compound 1.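

In this assay, hydrogen in place of bromo gives a 1.8-fold higher number from compound 2 to compound 4 (0.25 log units; within the scatter), so this change does not separate compound 2 from compound 4, and the 4-bromophenyl group shows no distinct contribution over phenyl. Hydrogen in place of fluoro gives an at least 1.5-fold lower number from compound 1 to compound 4 (0.19 log units; that floor lies within the scatter), so that step sets no firm order. Its size stays open because compound 1 is a limit rather than a number: the limit of > 100000 nM in this assay, at which 1 of the 4 values shown sits.

On these data alone, whether an amine or a carboxylic acid on this phenyl ring would move the number beyond the scatter remains open. Compound 3 differs from compound 4 in more than one place, so its value cannot be assigned to either change.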